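Series notes: amide in place of ester on the side chain

This account rests on a few compounds, and the source may have more. Where it says the series, first, only, none or still open, it means among the compounds named here.

Of the compounds shown here, three sharing one core have been read in an assay on isolated protein (strain Sprague-Dawley) for inhibition of Amine oxidase [flavin-containing] A (Rattus norvegicus), read by spectrophotometry, with a stated time of 5 min, tested at 10 uM; a higher number here means more inhibition at the concentration tested (going by the name of the read-out), a lower number less inhibition. Compound 1 `O=c1cc(O)c2ccc(OCc3cccc(Br)c3)cc2o1` gives 0%, compound 2 `CC(=O)COc1cc(=O)oc2cc(OCc3cccc(Cl)c3)ccc12` gives 22% and compound 3 `CCOC(=O)COc1cc(=O)oc2cc(OCc3cccc(Cl)c3)ccc12` gives 0%. Compound 3 thus stands level with compound 1 at the digits shown, the two together being the lowest numbers of the set, while compound 2 sits higher; the one step between measured neighbours, a number 22 percentage points lower from compound 2 to compound 3 (beyond the scatter), arose from ethoxy in place of methyl on a carbonyl carbon.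

Compound 4 `CN(C)C(=O)COc1cc(=O)oc2cc(OCc3cccc(Cl)c3)ccc12` is not yet measured. It differs from compound 3 by dimethylamino in place of ethoxy on a carbonyl carbon. For the measured compounds named here, no measured step covers dimethylamino at this carbonyl carbon; the only step touching that carbon is the modest drop from compound 2 to compound 3, and compound 3 already sits at the bottom of the scale, so there is little room for a further fall. In this assay compound 4 is therefore expected to stay near compound 3, with a step of about a number 5 percentage points higher from compound 3 to compound 4 (within the scatter), nothing beyond the scatter. The estimate for compound 4 is 5%, within 0% to 20%.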

Compound 4, a percentage reported as inhibition, at one concentration (the size of the read-out at that concentration, not a potency): 10%
The estimate for compound 4 lay 5 percentage points below the measured number; the range from low to high includes it.
By their numbers in this assay, from the lowest: compounds 1, 3 and 4 (each within the scatter of the next); then compound 2.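

In this assay the step of a number 10 percentage points higher from compound 3 to compound 4 (within the scatter) comes from dimethylamino in place of ethoxy on a carbonyl carbon, so this amide and the ester are not told apart at this position. The step of a number 12 percentage points lower from compound 2 to compound 4 (beyond the scatter) comes from dimethylamino in place of methyl on the same carbon, which shows that compound 2 stands clear of the amide as well as the ester and that the methyl group is the one that differs here. No measurement at hand explains why methyl stands apart from ethoxy and dimethylamino on this carbon.

Open, as far as these compounds go, is whether a carboxylic acid, a primary amide or a morpholine amide at this carbonyl carbon would read with compound 2 or with compound 3 and compound 4. Also open, from the compounds shown here alone, is whether an ethyl ketone or a longer ketone chain would keep the reading of compound 2.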